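A few compounds are considered here, and "the series" means these few. Any claim that something is new, unique, unknown or untested is made for them only; others in the source may bear on it.

Measured compounds:
compound 1 `C=CC1=C(C(=O)NC(C)(C)C)C(c2ccc(OC)cc2)OC1` gives > 100000 nM in a functional assay on SW480 cells (Homo sapiens) for cytotoxicity, read by MTT assay, with a stated time of 24 h; on this read-out higher numbers stand for weaker inhibition and lower numbers for stronger inhibition; this is a limit of the assay.
compound 2 `C=CC1=C(C(=O)NCC(C)C)C(c2ccc(F)cc2)OC1` gives > 100000 nM in this assay; this is a limit.
compound 3 `C=CC1=C(C(=O)NC(C)(C)C)C(c2ccc(F)cc2)OC1` gives > 100000 nM in this assay; this is a limit.

Compound 3 therefore stands only at a limit in this assay, as do the two others, which is what the limit of > 100000 nM in this assay, at which 3 of the 3 values shown sit, records. The steps a step that the two limits leave unreadable from compound 1 to compound 3 and a step that the two limits leave unreadable from compound 2 to compound 3 are both unreadable, since each end sits at the limit.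

Compound 4 `C=CC1=C(C(=O)Nc2cccc(C)c2)C(c2ccc(F)cc2)OC1` differs from compound 3 by 3-methylphenyl in place of tert-butyl on an amide-type nitrogen. Among the compounds with values here, no measured step bears on an aromatic substituent on the amide nitrogen; the one change at that nitrogen, a step that the two limits leave unreadable from compound 2 to compound 3, gives no size. The step of an at least 1.2-fold lower number from compound 3 to compound 4 (0.09 log units; that floor lies within the scatter) is thus expected to be small or unreadable, and compound 4 is estimated at 80000 nM, with a range of 20000 nM to 300000 nM, most likely again reported only as a limit.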

Compound 4, half-maximal inhibitory concentration: > 100000 nM
Compound 4 ended at the assay's limit (the forecaster's own chance of this, stated with the estimate: 65%); middle value at least 1.2-fold (0.09 log units) away from the limit.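

Compound 4 gives no readable step to compound 2 or compound 3, since all values are limits: the limit of > 100000 nM in this assay, at which 4 of the 4 values shown sit. On these data alone, whether any group on the amide-type nitrogen or aromatic carbon gives a readable value stays open.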